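The source may report more compounds than this note shows. Statements on the series, on what has been measured and on what is new or still open speak of the compounds shown alone.

Measured so far:
compound 1 `Cc1c(OCCCCOc2ccc(C(=O)O)c(Cl)c2)ccc(C(=O)CC(C)C)c1O` – 80.5%
compound 2 `Cc1c(OCCCCOc2ccc(C(=O)O)cc2)ccc(C(=O)CC(C)C)c1O` – 88%
compound 3 `COC(=O)c1ccc(OCCCCOc2ccc(C(=O)CC(C)C)c(C)c2C)cc1` – 15.9%

In an assay on HEK293 cells for positive allosteric modulation of metabotropic glutamate receptor 2 (Rattus norvegicus), read by thallium flux, with a stated time of 2.5 min (a higher number here means a larger maximal response, a lower number a smaller maximal response), compound 3 gives the lowest of the three numbers; compound 1 stands well above it, and compound 2 further still, both beyond the scatter. Going by the values given here, the only step between measured compounds that differ in a single place is a number 7.5 percentage points higher from compound 1 to compound 2 (within the scatter), which lies within the scatter and concerns a hydrogen in place of chloro on an aromatic carbon.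

Compound 4 `COC(=O)c1ccc(OCCCCOc2ccc(C(=O)CC(C)C)c(O)c2C)cc1` differs from compound 3 in one place: hydroxy in place of methyl on an aromatic carbon. Among the compounds with values here, no measured step involves this change, so nothing directly bears on it. Compound 1 and compound 2 both carry a hydroxy on the same aromatic carbon and give high maximal responses, but they also differ from compound 3 and compound 4 elsewhere, so their values can only hint. The expected step of a number 34.1 percentage points higher from compound 3 to compound 4 (beyond the scatter) is therefore upward but uncertain. Compound 4 is estimated to give 50%, with a range from 15% to 85%.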

Compound 4, largest response reached (reported as percent of maximum), in percent of the reference or control that the assay uses: 16.4%
For compound 4 the middle estimate is 33.6 percentage points above the measured one; low and high end bracket the measured number.
By their numbers in this assay, from the lowest: compounds 3 and 4 (each within the scatter of the next); then compounds 1 and 2 (each within the scatter of the next).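

In this assay, a hydroxy in place of methyl on this aromatic carbon, ortho to an isobutylcarbonyl group, leaves the methyl ester without a clear gain: the change gives a number 0.5 percentage points higher from compound 3 to compound 4 (within the scatter). The large difference lies at the other end of the molecule, where methyl in place of the acid hydrogen gives a number 71.6 percentage points lower from compound 2 to compound 4 (beyond the scatter), so the hydroxy alone does not carry the high response of compound 2. Replacing the whole chlorinated acid-bearing aryl group with the 4-(methoxycarbonyl)phenyl group gives a number 64.1 percentage points lower from compound 1 to compound 4 (beyond the scatter), though that step cannot separate the chloro from the ester.

The compounds shown leave open whether the hydroxy matters once the carboxylic acid is present, and how an amide would behave in the acid's place. Nothing available explains these differences.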